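Ethyl ester of the diethylsulfonamide acid: expected dose

The source may hold more compounds than are shown below. What is called first, only, known or untested is meant among the compounds shown, and "the series" means these compounds.

The series shares the core of compound 1 `CCOc1ccc(S(=O)(=O)Cl)cc1-c1ncc(C(=O)O)c(=O)[nH]1`, which carries a sulfonyl chloride and has no result in a functional assay on the whole organism (strain Sprague-Dawley) for inhibition, with Rattus norvegicus as the target, with a stated time of 10 min (on this read-out lower numbers stand for an effect already at smaller amounts and higher numbers for an effect only at larger amounts of compound), where compound 1 stands as "not determined" (no result reported). Within the data shown here, compound 2 `CCOc1ccc(S(=O)(=O)N(CC)CC)cc1-c1ncc(C(=O)O)c(=O)[nH]1` carries a diethylamino group on the sulfonyl sulfur together with a carboxy group; in this assay compound 2 gives 40 mg/kg, the only plain number in the set. Compound 3 `CCOc1ccc(S(=O)(=O)N(C)C(C)C)cc1-c1ncc(C(=O)O)c(=O)[nH]1` carries isopropyl(methyl)amino in place of diethylamino on the sulfonyl sulfur. In this assay compound 3 reaches only a limit, > 10 mg/kg; this is the limit of > 10 mg/kg in this assay, at which 1 of the 3 values shown sits. The step that the limit leaves unreadable from compound 2 to compound 3 cannot be sized.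

Compound 4 `CCOC(=O)c1cnc(-c2cc(S(=O)(=O)N(CC)CC)ccc2OCC)[nH]c1=O` differs from compound 2 at the carboxy group: ethyl in place of hydrogen on an oxygen next to a carbonyl group. Among the measured compounds shown here, no measured step touches that place, and the single measured step of the set is unreadable, so the numbers point in no direction. The working expectation for compound 4 is a step of no change at the digits printed from compound 2 to compound 4 (within the scatter) that stays within the scatter of the measurement. Compound 4 is accordingly estimated at 40 mg/kg in this assay, with an expected range from 15 mg/kg to 110 mg/kg; a limit in place of a number remains possible.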

Compound 4, dose for 50% inhibition: 10 mg/kg
Compound 4: middle estimate off by 4.0-fold (0.60 log units), on the high side; measured number below the stated range.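

Among these compounds, replacing the carboxy group with ethoxycarbonyl in this assay gives a 4.0-fold lower number from compound 2 to compound 4 (0.60 log units; beyond the scatter), the first readable step in the set and the first at this place. With the diethylamino group on the sulfonyl sulfur, the free carboxy hydrogen is therefore not needed for an effect in this whole-animal read-out, and ethyl on the oxygen next to the carbonyl group gives a lower dose, by a margin beyond the scatter. The values shown hold no measured property that accounts for this step.

The step on the sulfonyl sulfur remains unreadable, as compound 3 gives only a limit, > 10 mg/kg, and whether ethoxycarbonyl would have the same effect alongside isopropyl(methyl)amino is therefore open. Also open, as far as these compounds go, is whether the step depends on ethyl itself or would extend to other replacements at this place, such as a methyl ester, a longer chain such as a butyl ester, or a primary amide in place of the ester.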